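The source may hold more compounds than are shown below. What is called first, only, known or untested is meant among the compounds shown, and "the series" means these compounds.

Measured so far:
compound 1 `Cc1cc(C)cc(S(=O)(=O)c2cnc3cc(F)ccc3c2N2CCC(C)CC2)c1` — 80%
compound 2 `CC1CCN(c2c(S(=O)(=O)c3cc(F)cc(F)c3)cnc3c(F)cccc23)CC1` — 9%
compound 3 `CC1CCN(c2c(S(=O)(=O)c3ccccc3)cnc3cc(Cl)ccc23)CC1` — 93%

In an assay on isolated protein for displacement of a labelled ligand from metabotropic glutamate receptor 5 (Homo sapiens), with a stated time of 60 min, tested at 1 uM (a higher number here means more inhibition at the concentration tested (going by the name of the read-out), a lower number less inhibition), compound 2 gives 9%, the lowest of the three numbers; compound 1 sits well above it and compound 3 further still. Compound 4 `Cc1ccc(S(=O)(=O)c2cnc3c(F)cccc3c2N2CCC(C)CC2)cc1F` keeps the core of compound 2 and differs only in the group on the sulfonyl sulfur: 3-fluoro-4-methylphenyl in place of 3,5-difluorophenyl on a sulfonyl sulfur. Among the compounds with values here, no step between two measured compounds matches this change, so the comparison is indirect, and compounds 1 and 3 differ from compound 2 in the core as well. Because compound 1 gives 80% with a methyl-bearing aryl, the account expects a rise of a number 36 percentage points higher from compound 2 to compound 4 (beyond the scatter) from compound 2 to compound 4 in this assay, though with wide uncertainty. Compound 4 is estimated at 45%, between 10% and 85%.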

Compound 4, a percentage reported as inhibition, at one concentration (the size of the read-out at that concentration, not a potency): 93%
The estimate for compound 4 lay 48 percentage points below the measured number; measured number outside the range, above it.
By their numbers in this assay, from the lowest: compound 2; then compound 1; then compounds 3 and 4 (each within the scatter of the next).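

In this assay the group on the sulfonyl sulfur proves decisive with the core held fixed: 3-fluoro-4-methylphenyl in place of 3,5-difluorophenyl brings a large rise (a number 84 percentage points higher from compound 2 to compound 4 (beyond the scatter)). The low inhibition of compound 2 therefore does not follow from its core alone, which compound 4 shares. No measurement shown bears on why the step is so large. As far as these compounds go, it remains open whether the entering methyl or the departing fluorine accounts for the step, and how an aryl group carrying an amine or a carboxylic acid would behave on the sulfonyl sulfur.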